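The compounds below may be only part of what the source reports. "The series", "measured", "known", "first", "only" and "open" are said of these compounds alone.

Compound 2 `CC(=O)Nc1ccc(-c2nc3cc(C(F)(F)F)ccc3n2C)cc1` was tested in an ADME assay on MDBK cells (Bos taurus) for cytotoxicity, read by MTT assay, with a stated time of 96 h (a lower number here means that less compound is tolerated, a higher number that more compound is tolerated), where compound 2 gives 46000 nM. Its nearest relative is compound 1 `CN1CCN(CC(=O)Nc2ccc(-c3nc4cc(C(F)(F)F)ccc4n3C)cc2)CC1`, which in this assay gives 44000 nM. That step, a 1.0-fold higher number from compound 1 to compound 2 (0.02 log units; within the scatter), leaves the two standing together. Compound 3 `COc1ccc(-c2nc3cc([N+](=O)[O-])ccc3[nH]2)c(OC)c1OC` gives only a limit of the assay, > 100000 nM, which is the limit of > 100000 nM in this assay, at which 1 of the 3 values shown sits. Compound 4 `CCC(=O)Nc1ccc(-c2nc3cc(C(F)(F)F)ccc3n2C)cc1` differs from compound 2 by methyl in place of hydrogen on a saturated chain carbon bound to a carbonyl carbon. Going by the values given here, the one measured step at that same place, a saturated chain carbon bound to a carbonyl carbon, is a 1.0-fold higher number from compound 1 to compound 2 (0.02 log units; within the scatter), and it exchanged a far larger group than a methyl without shifting the number. A methyl entering there is therefore expected to bring no step beyond the scatter in this assay, namely no change at the digits printed from compound 2 to compound 4 (within the scatter). Compound 4 is estimated at 46000 nM, most likely between 23000 nM and 92000 nM.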

Compound 4, half-maximal cytotoxic concentration: > 100000 nM
Compound 4 ended at the assay's limit; the forecaster's own chance of this, stated with the estimate: 10%; middle value at least 2.1-fold (0.33 log units) away from the limit.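

Methyl in place of hydrogen on the saturated chain carbon bound to a carbonyl carbon gives an at least 2.1-fold higher number from compound 2 to compound 4 (0.33 log units; beyond the scatter), so this place is not as indifferent as the earlier step within the scatter suggested. Methyl in place of 4-methylpiperazin-1-yl gives an at least 2.2-fold higher number from compound 1 to compound 4 (0.35 log units; beyond the scatter), so here a single added carbon moves the number beyond the scatter. Both steps are only lower bounds, since the result for compound 4 is a limit of the assay: the limit of > 100000 nM in this assay, at which 2 of the 4 values shown sit.

Going by these compounds, how far compound 4 truly lies from compound 2 remains open. Also open, on these data alone, is whether a longer chain or a carboxylic acid at this place would keep the number at the limit or bring it back down.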